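Does inverted configuration change half-life in compound 4?

This account rests on a few compounds, and the source may have more. Where it says the series, first, only, none or still open, it means among the compounds named here.

Compound 1 (`COc1ccc(F)cc1-c1ccnc2[nH]c(C3=CCN([C@H]4CC[C@H](C(=O)O)CC4)CC3)cc12`) 3.3 h
Compound 2 (`COc1ccc(F)cc1-c1ccnc2[nH]c(C3=CCN([C@H]4CC[C@@H](C(=O)O)CC4)CC3)cc12`) 3.2 h
Compound 3 (`COc1ccc(F)cc1-c1c(F)cnc2[nH]c(C3=CCN([C@H]4CC[C@H](C(=O)O)CC4)CC3)cc12`) 3.5 h

In an ADME assay on the whole organism (Rattus norvegicus) for metabolic stability, at a dose of 1 mg/kg by the intravenous route (on this read-out higher numbers stand for a longer-lived compound and lower numbers for a shorter-lived compound), the three measured compounds sit level, and compound 3 lies within the usual scatter of both others. The next compound to consider is compound 4 (`COc1ccc(F)cc1-c1c(F)cnc2[nH]c(C3=CCN([C@H]4CC[C@@H](C(=O)O)CC4)CC3)cc12`) and its structural change is this: the two compounds have the same atoms and bonds and differ only in configuration as drawn: 2 of 2 stereo elements differ (all stereocentres are inverted: mirror images); a stereocentre at a saturated ring carbon is drawn r in compound 3 and s in compound 4; a stereocentre at a saturated ring carbon is drawn r in compound 3 and s in compound 4 and so nothing leaves or enters. Each stereocentre at a saturated ring carbon drawn r in compound 3 is drawn s in compound 4.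

Among the measured compounds shown here, two measured steps bear on this change. The same inversion, in a pair without the extra fluoro, gave a 1.0-fold lower number from compound 1 to compound 2 (0.01 log units; within the scatter) and stayed within the scatter. Placing fluoro in place of hydrogen on an aromatic carbon gave a 1.1-fold higher number from compound 1 to compound 3 (0.03 log units; within the scatter) and also stayed within the scatter. Because of a 1.0-fold lower number from compound 1 to compound 2 (0.01 log units; within the scatter) no step beyond the scatter is expected in this assay and neither direction is favoured. The expected step is a 1.0-fold lower number from compound 3 to compound 4 (0.01 log units; within the scatter) as an estimate only. The half-life expected for compound 4 is 3.4 h with an estimated range from 2.2 h to 5.2 h still to be tested by measurement.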

Compound 4, half-life: 3 h
Compound 4: the middle estimate sits 1.1-fold (0.05 log units) above what was measured; low and high end bracket the measured number.
By their numbers in this assay, from the lowest: compounds 4, 2, 1 and 3 (each within the scatter of the next).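

In this assay, the inversion has now been read with the extra fluoro in place, giving a 1.2-fold lower number from compound 3 to compound 4 (0.07 log units; within the scatter). Fluoro in place of hydrogen on an aromatic carbon, earlier seen on only one configuration, has now also been read on the other, giving a 1.1-fold lower number from compound 2 to compound 4 (0.03 log units; within the scatter). These four compounds therefore form a closed square in which neither change moves half-life beyond the scatter, and the fluoro step does not visibly depend on the configuration: the same change on two cores in this assay, a 1.1-fold higher number (0.03 log units; within the scatter) from compound 1 to compound 3 and a 1.1-fold lower number (0.03 log units; within the scatter) from compound 2 to compound 4, 1.1-fold (0.05 log units) apart, within the scatter of two such steps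

All four compounds carry the carboxylic acid, so they leave open how half-life would respond if an amide or a primary alcohol stood in its place. They also leave open whether a chloro or a methyl group in place of the new fluoro would stay as level.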